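Removing the 4-methylphenyl group from compound 3

The source may hold more compounds than are shown below. What is called first, only, known or untested is meant among the compounds shown, and "the series" means these compounds.

Compound 1 `O=C1O[C@H]([C@@H](O)Cn2cc(CNS(=O)(=O)c3ccc(F)cc3)nn2)C(OCc2ccccc2)=C1OCc1ccccc1`: 26800 nM
Compound 2 `O=C1O[C@H]([C@@H](O)Cn2cc(C3CC3)nn2)C(OCc2ccccc2)=C1OCc1ccccc1`: 25900 nM
Compound 3 `Cc1ccc(-c2cn(C[C@H](O)[C@H]3OC(=O)C(OCc4ccccc4)=C3OCc3ccccc3)nn2)cc1`: > 100000 nM

These values come from a functional assay on MCF7 cells (Homo sapiens) for antiproliferative activity, read by MTT assay, with a stated time of 72 h; on this read-out higher numbers stand for weaker inhibition and lower numbers for stronger inhibition. For compound 3 the value > 100000 nM is a limit, not a number. Compound 4 `O=C1O[C@H]([C@@H](O)Cn2ccnn2)C(OCc2ccccc2)=C1OCc1ccccc1` carries hydrogen in place of 4-methylphenyl on an aromatic carbon. Two measured steps bring that same group in: an at least 3.7-fold higher number from compound 1 to compound 3 (0.57 log units; beyond the scatter) and an at least 3.8-fold higher number from compound 2 to compound 3 (0.58 log units; beyond the scatter). The groups it replaced there show no difference beyond the scatter: a 1.0-fold lower number from compound 1 to compound 2 (0.01 log units; within the scatter). Within the data shown here, no measured compound carries hydrogen at this place, so the reasoning stretches. Removing 4-methylphenyl is still expected to give a lower number in this assay, a modest move. The expected step is an at least 2.5-fold lower number from compound 3 to compound 4 (0.39 log units; beyond the scatter). For compound 4 the estimated value is 40000 nM, with an expected range of 15000 nM to 100000 nM.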

Compound 4, half-maximal inhibitory concentration: > 100000 nM
Compound 4 gave a limit, no number (the forecaster's own chance of this, stated with the estimate: 30%); at least 2.5-fold (0.39 log units) between middle value and limit.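

In this assay compound 4 gives a limit and not a number, as compound 3 does, so the step between them cannot be read: the limit of > 100000 nM in this assay, at which 2 of the 4 values shown sit. With hydrogen on this aromatic carbon, the readable steps are an at least 3.8-fold higher number from compound 2 to compound 4 (0.58 log units; beyond the scatter) and an at least 3.7-fold higher number from compound 1 to compound 4 (0.57 log units; beyond the scatter). Taking away 4-methylphenyl therefore brings no measurable activity, and among these compounds only the cyclopropyl group of compound 2 and the sulfonylated aminomethyl group of compound 1 give numbers.

As far as these compounds go, whether a methyl group or an amine at this place would give a number stays open. From the compounds shown here alone, how weak compound 3 and compound 4 really are also stays open.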